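A few compounds are considered here, and "the series" means these few. Any claim that something is new, unique, unknown or untested is made for them only; others in the source may bear on it.

Working notes on the series: in a functional assay on PC-9 cells (Homo sapiens) for inhibition, read by MTT assay, with a stated time of 72 h (a higher number here means a weaker inhibitor, a lower number a stronger inhibitor), compound 1 `Cc1cc(Nc2cc(-c3ccccc3)[nH]n2)n2nc(SCc3cccc(Br)c3)nc2n1` gives 8900 nM, compound 2 `Cc1cc(Nc2cc(-c3ccccc3)[nH]n2)n2nc(SCc3ccccc3Br)nc2n1` gives 5630 nM and compound 3 `Cc1ccc(CSc2nc3nc(C)cc(Nc4cc(-c5ccccc5)[nH]n4)n3n2)cc1` gives 7310 nM, so compound 3 is not separated from the other two. Compound 4 `Cc1cc(Nc2cc(-c3ccccc3)[nH]n2)n2ncnc2n1` has hydrogen in place of (4-methylbenzyl)sulfanyl on an aromatic carbon. The measured steps only exchange the substituted phenyl on the sulfur-bound chain: a 1.6-fold lower number from compound 1 to compound 2 (0.20 log units; within the scatter), a 1.2-fold lower number from compound 1 to compound 3 (0.09 log units; within the scatter) and a 1.3-fold higher number from compound 2 to compound 3 (0.11 log units; within the scatter). Among the measured compounds shown here, none removes the whole group, and no measured compound lacks it, so they bear on this change only weakly. On judgement, a moderate step to a higher number in this assay is expected, with wide uncertainty. The estimated change is a 2.1-fold higher number from compound 3 to compound 4 (0.31 log units; beyond the scatter). Compound 4 is expected at 15000 nM, within an estimated range of 6000 nM to 40000 nM.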

Compound 4, half-maximal inhibitory concentration: > 50000 nM
Compound 4 gave a limit, no number; the forecaster's own chance of this, stated with the estimate: 25%; middle value at least 3.3-fold (0.52 log units) away from the limit.
By their numbers in this assay, from the lowest: compounds 2, 3 and 1 (each within the scatter of the next). At a limit, above all of these: compound 4.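

Hydrogen in place of the substituted benzyl sulfanyl groups on this aromatic carbon gives an at least 6.8-fold higher number from compound 3 to compound 4 (0.83 log units; beyond the scatter), an at least 8.8-fold higher number from compound 2 to compound 4 (0.94 log units; beyond the scatter) and an at least 5.6-fold higher number from compound 1 to compound 4 (0.74 log units; beyond the scatter), the first steps in the series beyond the scatter. Compound 4 gives a limit, not a number, in this assay: the limit of > 50000 nM in this assay, at which 1 of the 4 values shown sits. The exchanges on the phenyl did not separate compound 1, compound 2 and compound 3, whereas loss of the whole group does.

On these data alone, the true size of these steps stays open. So does whether a methylsulfanyl group or an amine on this carbon would keep the numbers of the benzyl sulfanyl compounds.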